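Replacing a naphthalene amide with a methoxypyridine amide

This account rests on a few compounds, and the source may have more. Where it says the series, first, only, none or still open, it means among the compounds named here.

The series shares one core, carried by compound 1 `COC(=O)c1scc(-c2ccc(NC(=O)c3ccc4ccccc4c3)cc2)c1OC`, and varies only the aromatic group attached at the carbonyl carbon. In an ADME assay on HEK293 cells (Homo sapiens) for cytotoxicity, read by MTT assay, with a stated time of 24 h (a lower number here means a stronger inhibitor, a higher number a weaker inhibitor), compound 1 gives "not determined" (no result reported), so its place on the numbers is open. Compound 2 `COC(=O)c1scc(-c2ccc(NC(=O)c3ccc(F)c(Cl)n3)cc2)c1OC` likewise gives "not determined" (no result reported) in this assay. The only numbered point comes from compound 3 `COC(=O)c1scc(-c2ccc(NC(=O)c3cccc(I)c3)cc2)c1OC`, which in this assay gives 42700 nM, a weak effect on cell viability.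

Compound 4 `COC(=O)c1scc(-c2ccc(NC(=O)c3ccc(OC)nc3)cc2)c1OC` is the unmeasured member. It differs from compound 1 in one place: 6-methoxypyridin-3-yl in place of naphthalen-2-yl on a carbonyl carbon. Among the compounds with values here, with no measured pair sharing this change, the size and direction of the step in this assay cannot be read from the data; the only anchor is the weak value of compound 3, and a result in the same weak region, or none beyond the scatter, is the working expectation.

Compound 4 is therefore estimated at 50000 nM in this assay, within a range from 15000 nM to 150000 nM.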

Compound 4, half-maximal inhibitory concentration: > 50000 nM
Compound 4: no number, only a limit; the forecaster's own chance of this, stated with the estimate: 40%; the middle value lies on the limit itself.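

In this assay compound 4 gives > 50000 nM, which is a limit of the assay and not a number. Within the data shown here, putting 6-methoxypyridin-3-yl in place of 3-iodophenyl on the carbonyl carbon amounts to an at least 1.1-fold higher number from compound 3 to compound 4 (0.06 log units; that floor lies within the scatter), so this pair shows no step that can be told from the scatter, although only a floor is known. A ring with a hetero atom at this position therefore leaves the reading in the same weak region as the iodinated ring of compound 3, with the reading of compound 4 stopping at the limit: the limit of > 50000 nM in this assay, at which 1 of the 4 values shown sits.

From the compounds shown here alone, the steps from compound 1 and compound 2 cannot be read, and how far compound 4 lies beyond its limit stays unknown. Going by these compounds, whether an amine or a carboxylic acid in place of the methoxy group would bring the reading into a measurable range also remains open.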